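The compounds below may be only part of what the source reports. "The series", "measured", "known", "first", "only" and "open" are said of these compounds alone.

Compound 3 `CN(Cc1cc(C(F)(F)F)cc(C(F)(F)F)c1)C(=O)c1c(CO)nc2ccccc2c1-c1ccccc1` carries a hydroxymethyl group on the shared core where compound 1 `CN(Cc1cc(C(F)(F)F)cc(C(F)(F)F)c1)C(=O)c1cnc2ccccc2c1-c1ccccc1` has hydrogen. In an in vitro assay on UC11MG cells for binding affinity to Substance-P receptor (Homo sapiens), read by radioligand binding (a lower number here means a stronger inhibitor, a higher number a weaker inhibitor), compound 1 gives 0.03 nM, compound 2 `O=C(NCc1cc(C(F)(F)F)cc(C(F)(F)F)c1)c1c(CBr)nc2ccccc2c1-c1ccccc1` gives 0.01 nM, and compound 3 gives 16 nM, the highest number of the three. Going by the values given here, the only measured step, a 530-fold higher number from compound 1 to compound 3 (2.73 log units; beyond the scatter), is large. Compound 4 `CN(Cc1cc(C(F)(F)F)cc(C(F)(F)F)c1)C(=O)c1c(CN)nc2ccccc2c1-c1ccccc1` differs from compound 3 by amino in place of hydroxy on a saturated chain carbon bound to an aromatic carbon. Among the compounds with values here, no measured step exchanges a hydroxy for an amino, so there is no direct precedent for this change in this assay; a step within the scatter or a modest shift in either direction is all that can reasonably be expected. Compound 4 is therefore expected to give about 10 nM, within a range from 2 nM to 60 nM. The expected step is a 1.6-fold lower number from compound 3 to compound 4 (0.20 log units; within the scatter).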

Compound 4, half-maximal inhibitory concentration: 9 nM
For compound 4 the middle estimate is 1.1-fold (0.05 log units) above the measured one; low and high end bracket the measured number.
By their numbers in this assay, from the lowest: compound 2; then compound 1; then compounds 4 and 3 (each within the scatter of the next).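

In this assay, amino in place of hydroxy on the saturated chain carbon stays within the scatter (a 1.8-fold lower number from compound 3 to compound 4 (0.25 log units; within the scatter)), so this exchange does not restore the low number of compound 1. Aminomethyl in place of hydrogen on the aromatic carbon is also a large step (a 300-fold higher number from compound 1 to compound 4 (2.48 log units; beyond the scatter)), so the rise seen with hydroxymethyl recurs with a second group at this position. No evidence is available to explain these results. From the compounds shown here alone, whether a methyl group, a carboxylic acid or a longer chain on this aromatic carbon would also raise the number remains open.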